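The source may hold more compounds than are shown below. What is called first, only, known or untested is meant among the compounds shown, and "the series" means these compounds.

Compound 1: `CC(/C=N/N(C)c1ccc([N+](=O)[O-])cc1)=N\NC(=O)c1cc([N+](=O)[O-])cc([N+](=O)[O-])c1` — 1110 nM
Compound 2: `COc1cc(C(=O)N/N=C(C)/C=N/Nc2ccc([N+](=O)[O-])cc2)ccc1O` — 5100 nM

Of the compounds shown here, two have been measured in a functional assay on cells (Splenocyte, Mus musculus, strain BALB/c) for inhibition, read by scintillation counting and thymidine incorporation, with a stated time of 72 h; on this read-out higher numbers stand for weaker inhibition and lower numbers for stronger inhibition. Compound 1 gives 1110 nM, and compound 2 gives 5100 nM, the higher of the two numbers; the gap between the pair is beyond the scatter, so compound 2 is the weaker inhibitor of the two in this assay.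

Compound 3, `CC(/C=N/Nc1ccc([N+](=O)[O-])cc1)=N\NC(=O)c1ccccc1Cl`, has not been measured. It differs from compound 2 in one place: 2-chlorophenyl in place of 4-hydroxy-3-methoxyphenyl on a carbonyl carbon. Among the measured compounds shown here, no measured pair shows this change by itself, so its effect cannot be read from a step already known. The account expects only a modest step, if any, in the direction of a lower number, roughly at the edge of the scatter.

Compound 3 is therefore estimated at 3000 nM in this assay, with a range from 800 nM to 12000 nM, which would mean an expected step of a 1.7-fold lower number from compound 2 to compound 3 (0.23 log units; within the scatter).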

Compound 3, half-maximal inhibitory concentration: > 12000 nM
Compound 3 gave a limit, no number; the forecaster's own chance of this, stated with the estimate: 10%; middle value at least 4.0-fold (0.60 log units) away from the limit.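

In this assay compound 3 gives > 12000 nM, which is a limit of the assay and not a number. Among the compounds shown here, the exchange of 4-hydroxy-3-methoxyphenyl for 2-chlorophenyl on a carbonyl carbon gives an at least 2.3-fold higher number from compound 2 to compound 3 (0.37 log units; beyond the scatter), so the group at this place does matter for inhibition in this assay, and this exchange weakens it, which the earlier compounds could not show. This reading rests on a single bound rather than on two numbers: the limit of > 12000 nM in this assay, at which 1 of the 3 values shown sits.

The compounds shown do not separate the departure of the hydroxy and methoxy groups from the arrival of the chlorine, since all of these change together in this one step. They also leave open how a plain phenyl group, or a phenyl group carrying an amine or a carboxylic acid, would read at this place.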